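Compound 3: a urea side-group swap at the assay limit

A few compounds are considered here, and "the series" means these few. Any claim that something is new, unique, unknown or untested is made for them only; others in the source may bear on it.

In a functional assay on HeLa cells (Homo sapiens) for inhibition, read by MTT assay, with a stated time of 72 h (on this read-out lower numbers stand for stronger inhibition and higher numbers for weaker inhibition), compound 1 `Cc1cccc(NC(=O)Nc2ccc(Oc3ncnc4[nH]ncc34)cc2)c1C` gives > 10000 nM, which is a limit and not a number. Compound 2 `COc1cccc(NC(=O)Nc2ccc(Oc3ncnc4c3cnn4C)cc2)c1` gives > 10000 nM, which is likewise a limit. Among the compounds with values here, compound 1 therefore has no measured potency to serve as a baseline, and the series so far shows (the limit of > 10000 nM in this assay, at which 2 of the 2 values shown sit).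

Compound 3 `O=C(NCC1CCCCC1)Nc1ccc(Oc2ncnc3[nH]ncc23)cc1` has cyclohexylmethyl in place of the 2,3-dimethylphenyl of compound 1 on an amide-type nitrogen: cyclohexylmethyl in place of 2,3-dimethylphenyl on an amide-type nitrogen.

Within the data shown here, no measured step is available to size this change. Among the measured compounds shown here, with the limit of > 10000 nM in this assay, at which 2 of the 2 values shown sit, as the only guide, no shift beyond the usual scatter is expected in this assay, and the estimated step is a step that the limit leaves unreadable from compound 1 to compound 3. A reading at the same limit is the likeliest result. For compound 3 the estimated half-maximal inhibitory concentration is 15000 nM, with an expected range from 5000 nM to 40000 nM.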

Compound 3, half-maximal inhibitory concentration: > 10000 nM
Compound 3: no number, only a limit (the forecaster's own chance of this, stated with the estimate: 75%); the middle value does not contradict the limit.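

Compound 3 gives > 10000 nM in this assay as a limit and not a number, so the step from compound 1 to compound 3 cannot be read. Left open is how compound 1, compound 2 and compound 3 rank in potency, as all stop at the same limit: the limit of > 10000 nM in this assay, at which 3 of the 3 values shown sit.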